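The source may report more compounds than this note shows. Statements on the series, on what has been measured and on what is new or still open speak of the compounds shown alone.

Measured compounds:
compound 1 `Oc1ccccc1/C=C/c1ccccc1O` — 24.3 ug/mL
compound 2 `Nc1ccccc1/C=C/c1ccccc1O` — 27 ug/mL
compound 3 `Oc1ccc(/C=C/c2cccc(O)c2)cc1` — 1.1 ug/mL

In an ADME assay on HEK293 cells (Homo sapiens) for inhibition, read by MTT assay, with a stated time of 2 days (on this read-out higher numbers stand for weaker inhibition and lower numbers for stronger inhibition), compound 1 gives 24.3 ug/mL and compound 2 gives 27 ug/mL; the step is a 1.1-fold higher number from compound 1 to compound 2 (0.05 log units; within the scatter), the change being (amino in place of hydroxy on an aromatic carbon). Compound 3 gives 1.1 ug/mL in this assay, the lowest number of the three; how its core differs from that of compound 1 is not broken down here.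

Compound 4 `Nc1ccc(/C=C/c2cccc(O)c2)cc1` is not yet measured. It differs from compound 3 by amino in place of hydroxy on an aromatic carbon. This is the same kind of change as from compound 1 to compound 2, but the place differs: there the entering group sits ortho to a group of 9 heavy atoms, here para to a group of 9 heavy atoms.

Because a 1.1-fold higher number from compound 1 to compound 2 (0.05 log units; within the scatter) lay within the scatter, the step from compound 3 to compound 4 in this assay is expected to be similarly small, a 1.4-fold higher number from compound 3 to compound 4 (0.13 log units; within the scatter). Compound 4 is estimated at 1.5 ug/mL in this assay, between 0.6 ug/mL and 4 ug/mL.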

Compound 4, half-maximal inhibitory concentration: 25 ug/mL
The estimate for compound 4 lay 17-fold (1.22 log units) below the measured number; the measured number lies above the stated range.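

In this assay amino in place of hydroxy on an aromatic carbon gives a 23-fold higher number from compound 3 to compound 4 (1.36 log units; beyond the scatter), so the size of this step does not carry from one core to the other: the same change on two cores in this assay, a 1.1-fold higher number (0.05 log units; within the scatter) from compound 1 to compound 2 and a 23-fold higher number (1.36 log units; beyond the scatter) from compound 3 to compound 4, 20-fold (1.31 log units) apart, beyond the scatter of two such steps. A near-silent swap on the core of compound 1 is thus no guide to the same swap on the core of compound 3. Among the compounds shown here, with only two pairs, the data do not show whether the place of the change or another difference between the cores lies behind the gap.

Open, on these data alone, is how a methoxy or an acetamide at the same place on the core of compound 3 would read. Also open, as far as these compounds go, is whether the large step holds on further cores.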